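The source may report more compounds than this note shows. Statements on the series, on what has been measured and on what is new or still open speak of the compounds shown alone.

Measured compounds:
- Compound 1, `CC1=NC(c2cn(S(=O)(=O)c3ccc(C)cc3)c3ccccc23)CN1`: 10000 nM
- Compound 2, `CC1=NC(c2cn(S(=O)(=O)c3ccc(Cl)cc3)c3ccccc23)CN1`: 5700 nM

These two compounds share one core and differ only in the group on the sulfonyl sulfur. In an assay on isolated protein for inhibition of kallikrein-7 (Homo sapiens), read by fluorescence, with stated times of 10 min and 30 min (on this read-out lower numbers stand for stronger inhibition and higher numbers for weaker inhibition), compound 1 gives 10000 nM, and compound 2 gives 5700 nM. Within the data shown here, the step of a 1.8-fold lower number from compound 1 to compound 2 (0.24 log units; within the scatter) is the only measured step, and compound 2 stands at the lower of the two numbers, though the gap to compound 1 is within the scatter, so no order can be claimed between them.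

Compound 3, `CC1=NC(c2cn(S(=O)(=O)c3cccc(Cl)c3)c3ccccc23)CN1`, has not yet been measured. Its change from compound 2 is 3-chlorophenyl in place of 4-chlorophenyl on a sulfonyl sulfur: the chlorine stays, the phenyl ring stays, only the arrangement differs. Among the measured compounds shown here, no measured step concerns a move of a chlorine on this ring; the one step known, from methyl to chloro, was itself within the scatter. There is therefore nothing to support a change beyond the scatter in this assay, in either direction. Compound 3 is expected to give about 5700 nM in this assay, a range of 2500 nM to 13000 nM, meaning an estimated step of no change at the digits printed from compound 2 to compound 3 (within the scatter).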

Compound 3, half-maximal inhibitory concentration: > 30000 nM
Compound 3: only a limit was reported (the forecaster's own chance of this, stated with the estimate: 15%); middle value at least 5.2-fold (0.72 log units) away from the limit.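

In this assay, the place of the chlorine on the phenyl ring matters even though the atoms stay the same: 3-chlorophenyl in place of 4-chlorophenyl gives an at least 5.2-fold higher number from compound 2 to compound 3 (0.72 log units; beyond the scatter), whereas chloro in place of methyl gave only a 1.8-fold lower number from compound 1 to compound 2 (0.24 log units; within the scatter). The change to 3-chlorophenyl from 4-methylphenyl on the sulfonyl sulfur likewise gives an at least 3.0-fold higher number from compound 1 to compound 3 (0.47 log units; beyond the scatter). The number for compound 3 is only a limit: the limit of > 30000 nM in this assay, at which 1 of the 3 values shown sits.

Going by these compounds, how far compound 3 truly lies from the other two compounds therefore stays open. The compounds shown also leave open whether an amine or a carboxylic acid in place of the chlorine of compound 2 would give a number clearly different from that of compound 2 in this assay.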